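A Methoxyphenyl Swap on the Ring Amine Nitrogen

The compounds below may be only part of what the source reports. "The series", "measured", "known", "first", "only" and "open" are said of these compounds alone.

compound 1 `Cc1c(C#N)c(-c2ccccc2)nn1CCCN1CCN(c2ccc(F)cc2)CC1`: 51%
compound 2 `CC(=O)c1cccn1CCCN1CCN(c2cccc(Cl)c2)CC1`: 54%
compound 3 `O=c1occ(-c2ccccc2)n1CCCN1CCN(c2ccc(F)cc2)CC1`: 34%

In a functional assay on the whole organism (Abdomen, strain Swiss) for inhibition, with Mus musculus as the target, with stated times of 30 min, 10 min and 5 min, at a dose of 40 mg/kg by the oral route (on this read-out higher numbers stand for a stronger effect at the one dose given and lower numbers for a weaker effect), compound 3 gives 34%, the lowest of the three numbers; compound 1 and compound 2 each stand higher by more than the usual scatter. Compound 4 `COc1cccc(N2CCN(CCCn3c(-c4ccccc4)coc3=O)CC2)c1` has not been tested. It differs from compound 3 in one place: 3-methoxyphenyl in place of 4-fluorophenyl on an amine nitrogen in a ring. Going by the values given here, no pair of measured compounds shows what such an exchange does, so its size cannot be read from the numbers at hand. The step from a number 4 percentage points higher from compound 3 to compound 4 (within the scatter) is therefore expected to stay within the scatter, with no clear direction. Compound 4 is estimated at 38%, in a range from 22% to 56%.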

Compound 4, a percentage reported as inhibition, in the whole organism at one dose (the size of the read-out at that dose, not a potency): 39%
Compound 4: middle estimate off by 1 percentage points, on the low side, within the range that was stated.
By their numbers in this assay, from the lowest: compounds 3 and 4 (each within the scatter of the next); then compounds 1 and 2 (each within the scatter of the next).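

In this assay, going by these compounds alone, this is the first measured exchange at the amine nitrogen in the ring: putting 3-methoxyphenyl in place of 4-fluorophenyl gives (a number 5 percentage points higher from compound 3 to compound 4 (within the scatter)). On this one pair, the aryl group on that nitrogen can change in this way, bringing in a hydrogen-bond acceptor, without a clear shift in the read-out. Nothing available here explains this result. Still open, as far as these compounds go, is what a carboxylic acid or an amine on that phenyl ring would do. From the compounds shown here alone, a plain phenyl group on the same nitrogen also remains open.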